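From furan-2-yl to furan-3-yl in the methoxy series

A few compounds are considered here, and "the series" means these few. Any claim that something is new, unique, unknown or untested is made for them only; others in the source may bear on it.

Compound 3 `COc1nc(N)nc2c1c(-c1ccco1)cn2[C@@H]1O[C@H](CO)[C@@H](O)[C@H]1O` gives > 20000 nM in a functional assay on HL-60 cells (Homo sapiens) for antiproliferative activity, read by XTT assay, with a stated time of 72 h (a higher number here means a weaker inhibitor, a lower number a stronger inhibitor), and this value is a limit, not a number. Compound 2 `Nc1nc(N)c2c(-c3ccco3)cn([C@@H]3O[C@H](CO)[C@@H](O)[C@H]3O)c2n1` gives > 20000 nM in this assay and this value is also a limit. The picture so far therefore rests largely on the limit of > 20000 nM in this assay, at which 2 of the 3 values shown sit, and not on measured numbers. Within the data shown here, the only number comes from compound 1 `CSc1ncnc2c1c(-c1cccs1)cn2[C@@H]1O[C@H](CO)[C@@H](O)[C@H]1O` which gives 1130 nM in this assay but differs from compound 3 in more than one place.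

Compound 4 `COc1nc(N)nc2c1c(-c1ccoc1)cn2[C@@H]1O[C@H](CO)[C@@H](O)[C@H]1O` differs from compound 3 by furan-3-yl in place of furan-2-yl on an aromatic carbon and the change is furan-3-yl in place of furan-2-yl on an aromatic carbon. Among the measured compounds shown here, the one measured step is a step that the two limits leave unreadable from compound 2 to compound 3 for methoxy in place of amino on an aromatic carbon. That step concerns another place and has no readable size, so it sets no scale for the furan change. The expectation rests on compound 3 with its limit of > 20000 nM as the only anchor. The expected change is a number no higher from compound 3 to compound 4 (the limit leaves the size open) in this assay with no step beyond the scatter and no direction expected. The estimate for compound 4 is 20000 nM with an expected range from 6000 nM to 40000 nM and a limit is the likeliest expected outcome.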

Compound 4, half-maximal inhibitory concentration: > 20000 nM
Compound 4 was reported as a limit; the forecaster's own chance of this, stated with the estimate: 80%; the middle value sits exactly at the limit.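

Compound 3 and compound 4 are both reported as limits in this assay, so no size can be read for the step to furan-3-yl in place of furan-2-yl. Still open is whether the two furan attachments differ at all in antiproliferative activity, as the series rests largely on a single limit: the limit of > 20000 nM in this assay, at which 3 of the 4 values shown sit.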